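Ring-amine substituent survey on the shared core

The source may report more compounds than this note shows. Statements on the series, on what has been measured and on what is new or still open speak of the compounds shown alone.

Compound 1 `CC(C)NC(=O)N1CCc2c(c(COc3cc(F)cc(F)c3)nn2C)C1` carries an isopropylurea on the ring amine nitrogen of the shared core. In an assay on cells for inhibition of Pendrin (Mus musculus), read by fluorescence, with a stated time of 10 min (a lower number here means a stronger inhibitor, a higher number a weaker inhibitor), compound 1 gives only a limit, > 10000 nM. Compound 2 `Cn1nc(COc2cc(F)cc(F)c2)c2c1CCN(C(=S)Nc1ccc(Cl)cc1)C2` also reaches only a limit in this assay, > 10000 nM. Compound 3 `Cn1nc(COc2cc(F)cc(F)c2)c2c1CCN(C(=S)NC1CCCCC1)C2` stands at a limit as well in this assay, > 10000 nM. The steps a step that the two limits leave unreadable from compound 1 to compound 2, a step that the two limits leave unreadable from compound 1 to compound 3 and a step that the two limits leave unreadable from compound 2 to compound 3 therefore carry no readable size, because of the limit of > 10000 nM in this assay, at which 3 of the 3 values shown sit.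

Compound 4 `Cn1nc(COc2cc(F)cc(F)c2)c2c1CCN(S(C)(=O)=O)C2` differs from compound 3 by a group of 4 heavy atoms (1 carbon, 2 oxygen, 1 sulfur; no ring) in place of a group of 9 heavy atoms (7 carbon, 1 nitrogen, 1 sulfur; one six-membered non-aromatic ring of carbon only), on an amine nitrogen in a ring. Among the measured compounds shown here, none of the measured steps bears readably on this change; all three of them start and end at the limit, so they give no direction and no size. For the measured compounds named here, compound 3 stands at the limit and nothing among the measured values supports a move below it. Compound 4 is therefore expected to remain near the limit in this assay, at 20000 nM, with a range from 5000 nM to 100000 nM. The step that the limit leaves unreadable from compound 3 to compound 4 is estimated to lie within the scatter.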

Compound 4, half-maximal inhibitory concentration: > 10000 nM
Compound 4: no number, only a limit; the forecaster's own chance of this, stated with the estimate: 80%; the middle value does not contradict the limit.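

In this assay compound 4 gives > 10000 nM as a limit only. Among the compounds shown here, no step from compound 1, compound 2 or compound 3 to compound 4 can be read, because all the values rest at one limit: the limit of > 10000 nM in this assay, at which 4 of the 4 values shown sit.

The compounds shown leave open whether any group on the ring amine nitrogen of the shared core gives a readable value.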